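The source may report more compounds than this note shows. Statements on the series, on what has been measured and on what is new or still open speak of the compounds shown alone.

Compound 2 `CCCC(=O)OCCCCOC(=O)c1ccc(C(=O)Nc2ccc3c(c2)C(C)(C)CCC3(C)C)cc1`: 7320 nM. Compound 1 `C=C(c1ccc(C(=O)NCCCCCCNC(=O)c2ccc(C(=O)Nc3ccc4c(c3)C(C)(C)CCC4(C)C)cc2)cc1)c1cc2c(cc1C)C(C)(C)CCC2(C)C`: 70700 nM.

In a functional assay on HL-60 cells (Homo sapiens) for inhibition, read by MTT assay, with a stated time of 48 h (on this read-out higher numbers stand for weaker inhibition and lower numbers for stronger inhibition), compound 2 gives 7320 nM and compound 1 gives 70700 nM. Compound 2 thus holds the lower of the two numbers, and its gap to compound 1 lies beyond the usual scatter. Compound 3 `CCCC(=O)OCCCOC(=O)c1ccc(C(=O)Nc2ccc3c(c2)C(C)(C)CCC3(C)C)cc1` has not yet been measured. It differs from compound 2 by (propylcarbonyl)oxy in place of ((propylcarbonyl)oxy)methyl on a saturated chain carbon, three bonds along the chain from an oxygen next to a carbonyl group, a shorter chain of the same kind. Among the measured compounds shown here, no measured pair shows this change. The step of a 1.0-fold lower number from compound 2 to compound 3 (0.00 log units; within the scatter) is expected to be none beyond the scatter. Compound 3 is estimated at 7300 nM, with a likely range from 3000 nM to 18000 nM.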

Compound 3, half-maximal inhibitory concentration: 2990 nM
Estimate against measurement, compound 3: 2.4-fold (0.39 log units) above; measured number below the stated range.
By their numbers in this assay, from the lowest: compound 3; then compound 2; then compound 1.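

Shortening the chain from 4-((propylcarbonyl)oxy)butyl to 3-((propylcarbonyl)oxy)propyl gives a 2.4-fold lower number from compound 2 to compound 3 (0.39 log units; beyond the scatter) in this assay. Among the compounds shown here, this modest step shows that the number responds to chain length at this saturated chain carbon, which the earlier compounds, differing in more than one place, could not show. No measurement here accounts for the step.

Two chain lengths cannot show whether the 2-((propylcarbonyl)oxy)ethyl chain or a longer chain would continue the direction. Going by these compounds, whether a carboxylic acid or an amine at the chain end would fit this position also stays open.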